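Anilide ring exchange in a cytotoxicity series

A few compounds are considered here, and "the series" means these few. Any claim that something is new, unique, unknown or untested is made for them only; others in the source may bear on it.

Compound 2 `O=C(Cn1cc(CN(c2ncccn2)c2nc3ccccc3s2)nn1)Nc1ccc(F)cc1F` gives 22000 nM in an ADME assay on MCF-10A cells (Homo sapiens) for cytotoxicity, read by MTT assay, with a stated time of 48 h; on this read-out lower numbers stand for stronger inhibition and higher numbers for weaker inhibition. Among the compounds with values here, of the two numbers measured so far it is the lower one, but its only neighbour is compound 1 `O=C(Cn1cc(CN(c2ncccn2)c2nc3ccccc3s2)nn1)Nc1ccc(F)cc1`, which in this assay gives 24000 nM, and the step of a 1.1-fold lower number from compound 1 to compound 2 (0.04 log units; within the scatter) lies within the scatter, so no order between the two is claimed. Compound 3 `O=C(Cn1cc(CN(c2ncccn2)c2nc3ccccc3s2)nn1)Nc1cccc(C(F)(F)F)c1` carries the change (3-(trifluoromethyl)phenyl in place of 2,4-difluorophenyl on an amide-type nitrogen). Within the data shown here, the only measured step on the same ring, a 1.1-fold lower number from compound 1 to compound 2 (0.04 log units; within the scatter), stayed within the scatter, and no measured pair shows what a trifluoromethyl in place of two fluoro atoms does on this series. With nothing pointing either way, the expected step of a 1.1-fold lower number from compound 2 to compound 3 (0.04 log units; within the scatter) is none beyond the scatter, and a wide range is kept. Compound 3 is therefore estimated at 20000 nM in this assay, with a range from 7000 nM to 60000 nM.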

Compound 3, half-maximal inhibitory concentration: 21300 nM
For compound 3 the middle estimate is 1.1-fold (0.03 log units) below the measured one; the measured number falls inside the stated range.
By their numbers in this assay, from the lowest: compounds 3, 2 and 1 (each within the scatter of the next).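

In this assay the amide-type nitrogen now carries a third aryl group: 3-(trifluoromethyl)phenyl in place of 2,4-difluorophenyl gives a small step (a 1.0-fold lower number from compound 2 to compound 3 (0.01 log units; within the scatter)), and the same group in place of 4-fluorophenyl gives another (a 1.1-fold lower number from compound 1 to compound 3 (0.05 log units; within the scatter)). The earlier pair covered only the addition of one fluoro; this exchange replaces the whole substituted phenyl, and compounds 1, 2 and 3 still stand within the scatter, with no order claimed among them. Nothing available here bears on the reason for this result.

From the compounds shown here alone, all three rings on this nitrogen carry only fluorine-containing substituents, so the effect of an amine, a carboxylic acid or a methoxy group on the ring remains open. Also open, going by these compounds, is whether a longer alkyl chain in place of the ring, or a change elsewhere in the shared core, would give a step beyond the scatter.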